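The source may report more compounds than this note shows. Statements on the series, on what has been measured and on what is new or still open speak of the compounds shown alone.

In a functional assay on HL-60 cells (Homo sapiens) for cytotoxicity, read by luminescence and CellTiter-Glo, with a stated time of 3 days (on this read-out lower numbers stand for stronger inhibition and higher numbers for weaker inhibition), compound 1 `N#Cc1ccc(NC(=O)c2cc(Cl)ccc2O)c(Cl)c1` gives 500 nM. Compound 2 `N#Cc1ccc(NC(=O)c2cc(F)ccc2O)cc1` gives 1420 nM in this assay, and compound 3 `O=C(Nc1ccc(OC(F)(F)F)cc1)c1cc(F)ccc1O` gives 850 nM. The difference between the core of compound 1 and the core of compound 2 is not broken down here. Compound 3 differs from compound 2 by trifluoromethoxy in place of cyano on an aromatic carbon, and that change brought a 1.7-fold lower number from compound 2 to compound 3 (0.22 log units; within the scatter). Compound 4 `O=C(Nc1ccc(OC(F)(F)F)cc1Cl)c1cc(Cl)ccc1O` has not yet been measured. It differs from compound 1 by trifluoromethoxy in place of cyano on an aromatic carbon, the same kind of change, though here the place is also meta to a chloro group. Compound 4 is expected to show a 1.6-fold lower number from compound 1 to compound 4 (0.19 log units; within the scatter) in this assay. That expectation rests on a 1.7-fold lower number from compound 2 to compound 3 (0.22 log units; within the scatter), a step within the scatter. Compound 4 is therefore estimated at 320 nM, with a likely range from 130 nM to 800 nM.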

Compound 4, half-maximal inhibitory concentration: 650 nM
For compound 4 the middle estimate is 2.0-fold (0.31 log units) below the measured one; the range from low to high includes it.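

In this assay the step of a 1.3-fold higher number from compound 1 to compound 4 (0.11 log units; within the scatter) came with trifluoromethoxy in place of cyano on the core of compound 1. Set beside the same change on the core of compound 2, this step does not differ from it: the same change on two cores in this assay, a 1.7-fold lower number (0.22 log units; within the scatter) from compound 2 to compound 3 and a 1.3-fold higher number (0.11 log units; within the scatter) from compound 1 to compound 4, 2.2-fold (0.34 log units) apart, within the scatter of two such steps
The change therefore carried across these two cores without a difference that can be told from scatter, but both steps are small, so the pair shows no real effect of the change on either core and says nothing about other cores.

The compounds shown leave open whether a different group in place of cyano, such as an amine or a carboxylic acid, would move the number beyond the scatter. Going by these compounds, whether the same holds on any third core also stays open.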